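Changing the Amide on the Side Chain of Compound 2

The source may hold more compounds than are shown below. What is called first, only, known or untested is meant among the compounds shown, and "the series" means these compounds.

Compound 2 `CC(=O)N(C)C[C@@H]1CCCc2cc(S(=O)(=O)c3cccc(F)c3)ccc21` is measured in an assay on isolated protein for displacement of a labelled ligand from 5-hydroxytryptamine receptor 6 (Homo sapiens) (a higher number here means a weaker inhibitor, a lower number a stronger inhibitor), where compound 2 gives 1.59 nM. Among the measured compounds shown here, compound 1 `CN(C[C@@H]1CCCc2cc(S(=O)(=O)c3cccc(F)c3)ccc21)S(N)(=O)=O` gives 3.98 nM in this assay, and the only step in hand is a 2.5-fold lower number from compound 1 to compound 2 (0.40 log units; beyond the scatter). Compound 2 thus stands at the lower of the two numbers. Compound 3 `CC(C)(C)C(=O)NC[C@@H]1CCCc2cc(S(=O)(=O)c3cccc(F)c3)ccc21` carries the change (((tert-butyl)carbonyl)amino in place of acetyl(methyl)amino on a saturated chain carbon bound to a saturated ring carbon). For the measured compounds named here, no measured step covers this kind of change: the single step, a 2.5-fold lower number from compound 1 to compound 2 (0.40 log units; beyond the scatter), swaps sulfamoyl for acetyl on the amine nitrogen and says nothing about a larger acyl group or about removing the methyl from that nitrogen. The expectation is therefore a step of a 1.9-fold higher number from compound 2 to compound 3 (0.28 log units; within the scatter), held to a size no larger than what the measured pair showed, with the direction uncertain. Compound 3 is estimated at 3 nM, within a range of 0.8 nM to 12 nM.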

Compound 3, inhibition constant: 3.98 nM
Estimate against measurement, compound 3: 1.3-fold (0.12 log units) below, and the stated range covers the measured number.
By their numbers in this assay, from the lowest: compound 2; then compounds 1 and 3 (each within the scatter of the next).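

In this assay, among the compounds shown here, ((tert-butyl)carbonyl)amino in place of acetyl(methyl)amino gives a 2.5-fold higher number from compound 2 to compound 3 (0.40 log units; beyond the scatter), the first step at this place that changes the acyl group and the substitution on the nitrogen together. Set against the methyl(sulfamoyl)amino side chain, the same group shows no change at the digits printed from compound 1 to compound 3 (within the scatter), so the two side chains are not told apart in this assay, and compound 2 keeps the lowest number of the three. No measurement is at hand that would explain either step.

The compounds shown leave open whether the higher number of compound 3 goes with the tert-butyl group or with the amide hydrogen that replaces the methyl. Acetylamino and ((tert-butyl)carbonyl)(methyl)amino on the same chain carbon would separate the two, while a free amine there would show what the acyl group contributes at all.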